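This account rests on a few compounds, and the source may have more. Where it says the series, first, only, none or still open, it means among the compounds named here.

Compound 2 `CCCSc1nc(N/N=C(\C)c2ccccc2O)c2nnn(Cc3ccccc3Cl)c2n1` sits at the edge of what the measurement can report. In a functional assay on MCF7 cells (Homo sapiens) for antiproliferative activity, read by MTT assay, with a stated time of 72 h (a lower number here means a stronger inhibitor, a higher number a weaker inhibitor), compound 2 gives > 64000 nM, which is a limit of the assay and not a number. Compound 1 `C#CCSc1nc(N/N=C/c2ccc(N(C)C)cc2)c2nnn(Cc3ccccc3)c2n1` gives > 64000 nM in this assay, again a limit. Compound 3 `CCCSc1nc(N/N=C/c2c[nH]c3ccccc23)c2nnn(Cc3ccccc3)c2n1` gives 9010 nM in this assay. So compound 2 stands at the limit of > 64000 nM in this assay, at which 2 of the 3 values shown sit, and no measured pair differs in only one place, so no step can be read off. The change to compound 4 `CCCSc1nc(N/N=C(\C)c2ccccc2O)c2nnn(Cc3ccccc3)c2n1` is hydrogen in place of chloro on an aromatic carbon. Within the data shown here, with no measured step to lean on, the expectation is a shift of a step that the limit leaves unreadable from compound 2 to compound 4, essentially none beyond the scatter. Compound 4 is therefore estimated at 70000 nM, in the range 20000 nM to 250000 nM.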

Compound 4, half-maximal inhibitory concentration: 11000 nM
Beside the measured number, compound 4's estimate is 6.4-fold (0.80 log units) above it, outside the stated range (below it).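

Hydrogen in place of chloro, which turns 2-chlorobenzyl into benzyl, gives the first readable step in this assay: there is an at least 5.8-fold lower number from compound 2 to compound 4 (0.76 log units; beyond the scatter) in this series. This shows that the group at this position matters, and here the chloro group goes with the weaker compound. Going by these compounds, the true size of the step stays unknown, because compound 2 stands at a limit of the assay: the limit of > 64000 nM in this assay, at which 2 of the 4 values shown sit.

Only chloro and hydrogen are shown at this position. On these data alone, a methyl or methoxy group there remains open, as does whether the step holds with other groups elsewhere on the molecule.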